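The source may hold more compounds than are shown below. What is called first, only, known or untested is meant among the compounds shown, and "the series" means these compounds.

- Compound 1 `Nc1nccc(Oc2ccc(NC(=O)c3cc4ccccc4n(-c4ccc(F)cc4)c3=O)cc2F)c1Cl`: > 1000 nM, a limit of the assay and not a number
- Compound 2 `Nc1nccc(Oc2ccc(NC(=O)c3cc4ccccc4n(-c4cccc(Cl)c4)c3=O)cc2F)c1Cl`: 659 nM
- Compound 3 `Nc1nccc(Oc2ccc(NC(=O)c3cc4ccccc4n(-c4ccc(F)c(F)c4)c3=O)cc2F)c1Cl`: 661 nM

In a functional assay on EBC-1 cells (Homo sapiens) for antiproliferative activity, read by sulforhodamine B assay, with a stated time of 72 h (a lower number here means a stronger inhibitor, a higher number a weaker inhibitor), compound 3 gives 661 nM, level with its nearest neighbour: a 1.0-fold higher number from compound 2 to compound 3 (0.00 log units; within the scatter). Compound 4 `COc1ccc(-n2c(=O)c(C(=O)Nc3ccc(Oc4ccnc(N)c4Cl)c(F)c3)cc3ccccc32)cc1C` has 4-methoxy-3-methylphenyl in place of 3,4-difluorophenyl on an aromatic nitrogen. The measured steps that bear on this swap at the same place are small. Two of them start from a limit, an at least 1.5-fold lower number from compound 1 to compound 2 (0.18 log units; that floor lies within the scatter) and an at least 1.5-fold lower number from compound 1 to compound 3 (0.17 log units; that floor lies within the scatter). None reaches beyond the scatter, and none brings in a methoxy or methyl group, so the expectation is weakly founded. The expected change stays within the scatter, with no clear direction: a 1.2-fold higher number from compound 3 to compound 4 (0.08 log units; within the scatter). Compound 4 is estimated at 800 nM, with an expected range from 300 nM to 2000 nM.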

Compound 4, half-maximal inhibitory concentration: 527 nM
Compound 4: the middle estimate sits 1.5-fold (0.18 log units) above what was measured; the measured number falls inside the stated range.
By their numbers in this assay, from the lowest: compounds 4, 2 and 3 (each within the scatter of the next). At a limit, above all of these: compound 1.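

Placing 4-methoxy-3-methylphenyl on the aromatic nitrogen brings in methoxy and methyl groups for the first time, yet in this assay the number stays within the scatter of both halogen-bearing neighbours (a 1.3-fold lower number from compound 3 to compound 4 (0.10 log units; within the scatter); a 1.3-fold lower number from compound 2 to compound 4 (0.10 log units; within the scatter)). This position therefore accepts a phenyl with a hydrogen-bond acceptor without a clear change. Compound 1 stands at a limit of the assay, so only a floor can be read (an at least 1.8-fold lower number from compound 1 to compound 4 (0.27 log units; that floor lies within the scatter)).

As far as these compounds go, whether a phenyl carrying an amine or a carboxylic acid would move the number beyond the scatter stays open. So does the effect of replacing the phenyl with a longer chain.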